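Replacing a naphthalene with a benzodioxin on the triazole core

This account rests on a few compounds, and the source may have more. Where it says the series, first, only, none or still open, it means among the compounds named here.

Of the compounds shown here, three of a shared core have been measured in a functional assay on A549 cells (Homo sapiens) for antiproliferative activity, with a stated time of 5 days; on this read-out higher numbers stand for weaker inhibition and lower numbers for stronger inhibition. Compound 1 `O=C1C=CC2(C=C1)OCC(=O)N2c1nc(-c2ccc3ccccc3c2)nn1-c1ccc(Cl)cc1` gives 400 nM. Compound 2 `CC1OC2(C=CC(=O)C=C2)N(c2nc(-c3cccc4ccccc34)nn2-c2ccccc2)C1=O` gives 180 nM, and compound 3 `O=C1C=CC2(C=C1)OCC(=O)N2c1nc(-c2cccc3ccccc23)nn1-c1ccccc1` gives 80 nM. Compound 3 thus stands lowest of the three numbers; its nearest neighbour is compound 2, and compound 1 lies furthest from it. For the measured compounds named here, the one step among the measured compounds that changes a single place is a 2.3-fold lower number from compound 2 to compound 3 (0.35 log units; beyond the scatter). Compound 1 differs from compound 3 in two places at once, so its higher number cannot be assigned to either change on its own.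

Compound 4 `O=C1C=CC2(C=C1)OCC(=O)N2c1nc(-c2ccc3c(c2)OCCO3)nn1-c1ccccc1` is the compound not yet measured. It differs from compound 3 by 2,3-dihydro-1,4-benzodioxin-6-yl in place of naphthalen-1-yl on an aromatic carbon. Going by the values given here, none of the measured steps touches the aromatic group at this position, so no measured step bears directly on this change, and the only guidance is that compound 3 holds the lowest number of the series. On that footing a modest move toward a higher number is expected, a 2.5-fold higher number from compound 3 to compound 4 (0.40 log units; beyond the scatter), though the direction is uncertain. Compound 4 is therefore estimated at 200 nM, within a range from 60 nM to 700 nM.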

Compound 4, half-maximal inhibitory concentration: 170 nM
The estimate for compound 4 lay 1.2-fold (0.07 log units) above the measured number; measured number inside the range.
By their numbers in this assay, from the lowest: compound 3; then compounds 4 and 2 (each within the scatter of the next); then compound 1.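

In this assay, for the compounds shown here, the step of a 2.1-fold higher number from compound 3 to compound 4 (0.33 log units; beyond the scatter) gives the first measured reading of a change on the aromatic carbon of the five-membered ring with 3 nitrogen, where 2,3-dihydro-1,4-benzodioxin-6-yl replaces naphthalen-1-yl. The number at this position thus responds to the group it carries, even with the heavy-atom count unchanged, although the step is modest: the entering group keeps one six-membered aromatic ring of carbon only, exchanges the second for a six-membered non-aromatic ring with 2 hetero atoms, and brings 2 hydrogen-bond acceptors where the leaving group has none. No measured evidence is available to explain this step.

The swap alters the ring type, the oxygen atoms and the point of attachment together, so the compounds shown do not tell which of these changes accounts for the step. Also open, from the compounds shown here alone, is how a plain phenyl group, a 4-methoxyphenyl group or a 1,3-benzodioxol-5-yl group would read at this position on the same core, with the phenyl group on the ring nitrogen kept in place.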